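From 4-propylphenyl to 3-methoxyphenyl on the amide nitrogen

The source may report more compounds than this note shows. Statements on the series, on what has been measured and on what is new or still open speak of the compounds shown alone.

In a functional assay on A549 cells (Homo sapiens) for inhibition, read by MTT assay, with a stated time of 72 h (a higher number here means a weaker inhibitor, a lower number a stronger inhibitor), compound 2 (`CCCc1ccc(NC(=O)C2CCN(C/C=C/c3ccccc3)CC2)cc1`) gives 9470 nM and compound 3 (`CCCCc1ccc(NC(=O)C2CCN(C/C=C/c3ccccc3)CC2)cc1`) gives 5910 nM within the scatter of it, while compound 1 (`Cc1ccc(NC(=O)C2CCN(C/C=C/c3ccccc3)CC2)cc1`) stands clearly higher at 29600 nM on the same scale.

The change to compound 4 (`COc1cccc(NC(=O)C2CCN(C/C=C/c3ccccc3)CC2)c1`) is 3-methoxyphenyl in place of 4-propylphenyl on an amide-type nitrogen and puts 3-methoxyphenyl in place of 4-propylphenyl on an amide-type nitrogen. Within the data shown here, no measured compound carries a methoxy group, so the available steps bear on this change only indirectly. The closest evidence concerns the saturated chain: a 3.1-fold lower number from compound 1 to compound 2 (0.49 log units; beyond the scatter) and a 5.0-fold lower number from compound 1 to compound 3 (0.70 log units; beyond the scatter) were both modest, whereas a 1.6-fold lower number from compound 2 to compound 3 (0.20 log units; within the scatter) stayed within the scatter. With the propyl chain gone, a modest move back towards compound 1 is expected, of about the size of a 3.1-fold lower number from compound 1 to compound 2 (0.49 log units; beyond the scatter) but in the opposite direction.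

The estimated step is a 2.3-fold higher number from compound 2 to compound 4 (0.37 log units; beyond the scatter) towards a weaker inhibitor. Compound 4 is expected at 22000 nM in this assay with an estimated range from 9000 nM to 55000 nM for this read-out.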

Compound 4, half-maximal inhibitory concentration: 50500 nM
For compound 4 the middle estimate is 2.3-fold (0.36 log units) below the measured one, and the stated range covers the measured number.
By their numbers in this assay, from the lowest: compounds 3 and 2 (each within the scatter of the next); then compounds 1 and 4 (each within the scatter of the next).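

On an amide-type nitrogen, 3-methoxyphenyl in place of 4-propylphenyl gives a 5.3-fold higher number from compound 2 to compound 4 (0.73 log units; beyond the scatter) in this assay, so the lower numbers seen with the 4-propylphenyl and 4-butylphenyl amides are not retained with this group. Against the 4-methylphenyl amide, the same group gives a 1.7-fold higher number from compound 1 to compound 4 (0.23 log units; within the scatter), so 3-methoxyphenyl and 4-methylphenyl are not told apart at this position. Nothing shown accounts for the size of the step from the propyl compound.

The change replaces the propyl chain with a methoxy group and alters the substitution on the phenyl ring in one step, and no compound shown separates these two changes. As far as these compounds go, whether 4-methoxyphenyl or 3-propylphenyl would match compound 2 or compound 4 stays open, as does the effect of a pentyl chain or an amine on the phenyl ring.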